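The source may hold more compounds than are shown below. What is called first, only, known or untested is meant among the compounds shown, and "the series" means these compounds.

In an ADME assay on MT4 cells (Homo sapiens) for cytotoxicity, read by MTT assay, with a stated time of 5 days (on this read-out higher numbers stand for lower toxicity in this test and lower numbers for higher toxicity in this test), compound 1 `COc1cc2nc(SCC(=O)Nc3ccc(C#N)cc3)nc(Nc3c(C)cc(/C=C/C#N)cc3C)c2cc1OC` is reported only as a limit, > 227000 nM. Compound 2 `COc1cc2nc([S+]([O-])CC(=O)Nc3ccc([N+](=O)[O-])cc3)nc(Nc3c(C)cc(/C=C/C#N)cc3C)c2cc1OC` gives 189000 nM, and compound 3 `COc1cc2nc([S+]([O-])CC(=O)Nc3ccc([N+](=O)[O-])cc3)nc(Nc3c(Cl)cc(/C=C/C#N)cc3Cl)c2cc1OC` gives 92800 nM, the lowest number of the three. Compound 4 `COc1cc2nc([S+]([O-])CC(=O)Nc3cccc(C(F)(F)F)c3)nc(Nc3c(Cl)cc(/C=C/C#N)cc3Cl)c2cc1OC` differs from compound 3 at one place, (3-(trifluoromethyl)phenyl in place of 4-nitrophenyl on an amide-type nitrogen), with 3-(trifluoromethyl)phenyl in place of 4-nitrophenyl on an amide-type nitrogen. Within the data shown here, the only measured step, a 2.0-fold lower number from compound 2 to compound 3 (0.31 log units; beyond the scatter), was modest and lay at another place in the molecule, so no measured step bears directly on this change. In this assay, no clear direction and no step beyond the scatter are therefore expected, and the expected step is a 1.2-fold lower number from compound 3 to compound 4 (0.06 log units; within the scatter). For compound 4 the estimated value is 80000 nM, with an expected range from 25000 nM to 230000 nM.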

Compound 4, half-maximal cytotoxic concentration: 21800 nM
Estimate against measurement, compound 4: 3.7-fold (0.56 log units) above, outside the stated range (below it).
By their numbers in this assay, from the lowest: compound 4; then compound 3; then compound 2. At a limit, above all of these: compound 1.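

In this assay, the group on the amide-type nitrogen also moves the number: a 4.3-fold lower number from compound 3 to compound 4 (0.63 log units; beyond the scatter). Among these compounds, the earlier measured step lay at another place in the molecule, so this is the first sign that this position affects the read-out, and here the swap of 4-nitrophenyl for 3-(trifluoromethyl)phenyl lowers it. Nothing measured here accounts for the step. The compounds shown leave open whether the nitro group's loss, the trifluoromethyl group's arrival or the changed ring position carries the step. They also leave open what a plain phenyl or a longer alkyl chain on this nitrogen would give.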